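Cyclopentylamino to piperidin-1-yl in a weak series

The compounds below may be only part of what the source reports. "The series", "measured", "known", "first", "only" and "open" are said of these compounds alone.

In a functional assay on ECa-109 cells for inhibition, with ECa-109 cell line (Homo sapiens) as the target, read by sulforhodamine B assay (a lower number here means a stronger inhibitor, a higher number a weaker inhibitor), the measured compounds stand as follows:
Compound 1 (`O=C1C=C(NCc2ccccc2)C(=O)c2c1nc1n2[C@H]2OC[C@@H](O)[C@H]2OC1`): > 8000 nM (a limit)
Compound 2 (`O=C1C(NC2CCCC2)=CC(=O)c2c1nc1n2[C@H]2OC[C@@H](O)[C@H]2OC1`): > 16000 nM (a limit)
Compound 3 (`CCc1ccc(NC2=CC(=O)c3nc4n(c3C2=O)[C@H]2OC[C@@H](O)[C@H]2OC4)cc1`): 3080 nM (a number)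

Compound 2 stands at a limit of this assay and has no number. Compound 4 (`O=C1C(N2CCCCC2)=CC(=O)c2c1nc1n2[C@H]2OC[C@@H](O)[C@H]2OC1`) carries piperidin-1-yl in place of cyclopentylamino on a double-bonded ring carbon, a change counted as piperidin-1-yl in place of cyclopentylamino on a double-bonded ring carbon with the same atoms joined differently. Within the data shown here, the one measured step, an at least 2.5-fold lower number from compound 1 to compound 3 (0.41 log units; beyond the scatter), puts 4-ethylphenyl in place of benzyl on an amine nitrogen and bears on this change only loosely. No step beyond the scatter is therefore expected, and the estimated step is an at least 1.1-fold lower number from compound 2 to compound 4 (0.05 log units; that floor lies within the scatter) in this assay here. For compound 4 the expected value is 14000 nM, within an estimated range of 4000 nM to 40000 nM overall.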

Compound 4, half-maximal inhibitory concentration: > 8000 nM
Compound 4: a limit, no number; the forecaster's own chance of this, stated with the estimate: 55%; the middle value does not contradict the limit.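

Compound 2 and compound 4 both stand at limits in this assay, and no step can be read between them. The compounds shown leave open whether piperidin-1-yl or cyclopentylamino on a double-bonded ring carbon gives the stronger inhibitor.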